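A Smaller Saturated Group at the Aromatic Carbon

This account rests on a few compounds, and the source may have more. Where it says the series, first, only, none or still open, it means among the compounds named here.

The measured compounds and their values:
- compound 1, `O=C(O)c1ccccc1-c1ccc(CCc2ncc(C3CCCCC3)[nH]2)cc1`: in an in vitro functional assay on cells for agonist activity at Bombesin receptor subtype-3 (Mus musculus), read by luminescence and calcium flux (on this read-out higher numbers stand for an effect only at larger amounts of compound and lower numbers for an effect already at smaller amounts), compound 1 gives 14.7 nM
- compound 2, `O=C(O)c1ccccc1-c1ccc(CCc2ncc(Cc3ccccc3Cl)[nH]2)cc1`: in this assay compound 2 gives 22 nM
- compound 3, `N#Cc1cccc(Cc2cnc(CCc3ccc(-c4ccccc4C(=O)O)cc3)[nH]2)c1`: in this assay compound 3 gives 20 nM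

Compound 1 holds the lowest of the three numbers in this assay, but its neighbours stand close: a 1.4-fold higher number from compound 1 to compound 3 (0.13 log units; within the scatter) and a 1.5-fold higher number from compound 1 to compound 2 (0.18 log units; within the scatter), so none of the three can be set apart from the others. The step of a 1.1-fold lower number from compound 2 to compound 3 (0.04 log units; within the scatter) likewise shows no separation.

Compound 4, `O=C(O)c1ccccc1-c1ccc(CCc2ncc(CC3CC3)[nH]2)cc1`, has not yet been measured. It differs from compound 1 in one place: cyclopropylmethyl in place of cyclohexyl on an aromatic carbon. The measured steps bearing on this position all swap the cyclohexyl of compound 1 for another group on the same aromatic carbon, and each of them, a 1.5-fold higher number from compound 1 to compound 2 (0.18 log units; within the scatter) and a 1.4-fold higher number from compound 1 to compound 3 (0.13 log units; within the scatter), stayed within the scatter. A smaller saturated group has not been tried at this position, so the outcome is less certain than for an aromatic replacement. On the evidence in hand, compound 4 is expected to give a number close to that of compound 1, with the step of a 1.7-fold higher number from compound 1 to compound 4 (0.23 log units; within the scatter) estimated to lie within the scatter. The estimate for compound 4 in this assay is 25 nM, with a range from 9 nM to 70 nM.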

Compound 4, half-maximal effective concentration: 72 nM
The estimate for compound 4 lay 2.9-fold (0.46 log units) below the measured number; measured number outside the range, above it.
By their numbers in this assay, from the lowest: compounds 1, 3 and 2 (each within the scatter of the next); then compound 4.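

For the compounds shown here, this position turns out not to be indifferent to the group it carries: in this assay, a 4.9-fold higher number from compound 1 to compound 4 (0.69 log units; beyond the scatter) is the first step at this aromatic carbon to go beyond the scatter, whereas cyclohexyl, 2-chlorobenzyl and 3-cyanobenzyl could not be told apart. Cyclopropylmethyl also separates from both benzyl groups, with a 3.6-fold higher number from compound 3 to compound 4 (0.56 log units; beyond the scatter) and a 3.3-fold higher number from compound 2 to compound 4 (0.51 log units; beyond the scatter), so on the same saturated chain carbon cyclopropyl does not match 3-cyanophenyl or 2-chlorophenyl, although all three steps are modest. Nothing at hand accounts for this shift in the number.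

The compounds shown do not separate the two differences between cyclohexyl and cyclopropylmethyl, the smaller ring and the saturated chain carbon that links it to the aromatic carbon; cyclohexylmethyl and a cyclopropyl group set directly on the aromatic carbon would divide the two. They also leave open how this position responds to a saturated ring carrying an amine or a hydroxyl group, or to an open chain such as butyl, and whether any such group would bring the number back towards that of compound 1.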